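Compound 2 to compound 3: a benzyl group enters

The source may hold more compounds than are shown below. What is called first, only, known or untested is meant among the compounds shown, and "the series" means these compounds.

Within the data shown here, in an ADME assay for pharmacokinetics (on this read-out lower numbers stand for a shorter-lived compound and higher numbers for a longer-lived compound), compound 2 `CC(=O)Nc1ccc2c(Cl)c(OCCCSC(=N)N)oc(=O)c2c1` gives 1.13 h, the lower of the two numbers so far. Compound 1 `N=C(N)SCCCOc1oc(=O)c2cc(NC(=O)NCc3ccccc3)ccc2c1Cl` gives 2.47 h. Compound 3 `N=C(N)SCCCOc1oc(=O)c2cc(NC(=O)CCc3ccccc3)ccc2c1Cl` has not yet been measured. Its change from compound 2 is benzyl in place of hydrogen on a saturated chain carbon bound to a carbonyl carbon, on a saturated chain carbon bound to a carbonyl carbon. Read one bond further out, this is methyl to phenethyl. Among the measured compounds shown here, only one measured step bears on it: a 2.2-fold lower number from compound 1 to compound 2 (0.34 log units; beyond the scatter), with methyl in place of benzylamino on a carbonyl carbon. That step is modest but beyond the scatter. It is also a different change, so the evidence is thin. A rise of similar modest size is therefore expected in this assay, and the estimate is a 2.1-fold higher number from compound 2 to compound 3 (0.33 log units; beyond the scatter). For compound 3 the expected value is 2.4 h, with an estimated range of 1.3 h to 4.2 h.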

Compound 3, half-life: 1.1 h
For compound 3 the middle estimate is 2.2-fold (0.34 log units) above the measured one; the whole stated range lies above it.
By their numbers in this assay, from the lowest: compounds 3 and 2 (each within the scatter of the next); then compound 1.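

In this assay, benzyl in place of hydrogen on a saturated chain carbon bound to a carbonyl carbon gives a 1.0-fold lower number from compound 2 to compound 3 (0.01 log units; within the scatter), so methyl to phenethyl has no readable effect at this place. Replacing the benzylamino group with phenethyl gives a 2.2-fold lower number from compound 1 to compound 3 (0.35 log units; beyond the scatter), and replacing it with methyl gives a 2.2-fold lower number from compound 1 to compound 2 (0.34 log units; beyond the scatter), which leaves the benzylamino compound alone at the higher number and shows that an added aromatic ring does not by itself reproduce it. No measurement in hand accounts for this difference.

As far as these compounds go, it remains open whether the nitrogen of the benzylamino group is what sets compound 1 apart, or whether the chain joining the ring to the carbonyl carbon matters. A phenylamino group or a longer chain ending in an amine on the carbonyl carbon would bear on that question.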